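The compounds below may be only part of what the source reports. "The series", "measured", "known", "first", "only" and "open" are said of these compounds alone.

Within the data shown here, compound 2 `Cc1cc(F)cc(Nc2cc(NC(=O)Nc3c(Cl)cccc3Cl)ncn2)c1` has the higher number of the two compounds measured so far. In a functional assay on NCI-H520 cells (Homo sapiens) for inhibition, read by MTT assay, with a stated time of 48 h, tested at 10 uM (on this read-out higher numbers stand for more inhibition at the one concentration tested (going by the name of the read-out) and lower numbers for less inhibition), compound 2 gives 60.5%. Among the measured compounds shown here, its only neighbour, compound 1 `COc1ccc(F)cc1Nc1cc(NC(=O)Nc2c(Cl)cccc2Cl)ncn1`, gives 38.1% in this assay, and the single measured step, a number 22.4 percentage points higher from compound 1 to compound 2 (beyond the scatter), runs from the 5-fluoro-2-methoxyphenyl group to the 3-fluoro-5-methylphenyl group on the same nitrogen.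

Compound 3 `COc1cc(Br)ccc1Nc1cc(NC(=O)Nc2c(Cl)cccc2Cl)ncn1` differs from compound 2 at that same nitrogen: 4-bromo-2-methoxyphenyl in place of 3-fluoro-5-methylphenyl on a nitrogen on an aromatic ring. For the measured compounds named here, the one measured step bears directly on this, since compound 3, like compound 1, carries a methoxyphenyl group there and compound 1 scored lower. So a downward step beyond the scatter is expected, but smaller than the full measured one because compound 1 gives 38.1% with a pattern that compound 3 only partly shares.

The expected step from compound 2 to compound 3 is a number 15.5 percentage points lower from compound 2 to compound 3 (beyond the scatter). The estimate for compound 3 is 45%, within 25% to 65%.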

Compound 3, a percentage reported as inhibition, at one concentration (the size of the read-out at that concentration, not a potency): 29.1%
Estimate against measurement, compound 3: 15.9 percentage points above; low and high end bracket the measured number.
By their numbers in this assay, from the lowest: compounds 3 and 1 (each within the scatter of the next); then compound 2.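

In this assay, 4-bromo-2-methoxyphenyl in place of 3-fluoro-5-methylphenyl on the nitrogen gives a number 31.4 percentage points lower from compound 2 to compound 3 (beyond the scatter), so a second methoxyphenyl group also falls well short of the group in compound 2. The two methoxyphenyl groups cannot be told apart here: the change from 5-fluoro-2-methoxyphenyl to 4-bromo-2-methoxyphenyl gives a number 9 percentage points lower from compound 1 to compound 3 (within the scatter), and swapping the halogen and moving it make no clear difference in this pair. Nothing measured here explains the drop.

Whether the methoxy group, the halogen or the methyl group accounts for the gap stays open, as each step to compound 2 changes several parts of the ring together. How a plain phenyl group, or an amine on this ring, would score is also unknown from these compounds.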